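Swapping the Pyridine Amide for a Benzamide

A few compounds are considered here, and "the series" means these few. Any claim that something is new, unique, unknown or untested is made for them only; others in the source may bear on it.

Compound 1 `COc1cccc(-c2nc3c(-c4ccc(Cl)cc4)n[nH]c3c(=O)n2NC(=O)c2ccncc2)c1` stands highest of the two numbers measured in a functional assay on SK-MEL-2 cells (Homo sapiens) for cytotoxicity, read by sulforhodamine B assay, with a stated time of 2 days, tested at 100 uM; on this read-out lower numbers stand for less inhibition and higher numbers for more inhibition at the one concentration tested (going by the name of the read-out); compound 1 gives 39.6%. Compound 2 `COc1cccc(-c2nc3c(-c4ccc(C5CCNCC5)cc4)n[nH]c3c(=O)n2NC(=O)c2ccncc2)c1`, which carries piperidin-4-yl in place of chloro on an aromatic carbon, gives 23.4%, a change of a number 16.2 percentage points lower from compound 1 to compound 2 (beyond the scatter). Compound 3 `COc1cccc(-c2nc3c(-c4ccc(Cl)cc4)n[nH]c3c(=O)n2NC(=O)c2ccccc2)c1` differs from compound 1 at another place: phenyl in place of pyridin-4-yl on a carbonyl carbon. Among the measured compounds shown here, the only measured step, from compound 1 to compound 2, alters a different part of the shared core, and no measured pair touches the group on the carbonyl carbon. No step beyond the scatter is therefore expected for compound 3 in this assay. The step from compound 1 to compound 3 is estimated at a number 2.6 percentage points lower from compound 1 to compound 3 (within the scatter). Compound 3 is expected to give about 37%, with a likely range from 20% to 55%.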

Compound 3, a percentage reported as inhibition, at one concentration (the size of the read-out at that concentration, not a potency): 84.9%
Compound 3: the middle estimate sits 47.9 percentage points below what was measured; measured number outside the range, above it.
By their numbers in this assay, from the lowest: compound 2; then compound 1; then compound 3.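

In this assay, the group on the carbonyl carbon proves to be a strong handle: phenyl in place of pyridin-4-yl gives a number 45.3 percentage points higher from compound 1 to compound 3 (beyond the scatter), a larger step than the one at the chloro position, a number 16.2 percentage points lower from compound 1 to compound 2 (beyond the scatter). This large step comes from a change that keeps six heavy atoms and one six-membered aromatic ring, replacing a ring nitrogen with carbon and leaving no hydrogen-bond acceptor in the group. Nothing available here accounts for the size of this step.

The compounds shown leave open whether phenyl would bring a similar step when paired with the piperidin-4-yl group of compound 2. They also leave open how the number would respond to an amine or a carboxylic acid on that phenyl ring.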